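This account rests on a few compounds, and the source may have more. Where it says the series, first, only, none or still open, it means among the compounds named here.

In a functional assay on K562 cells (Homo sapiens) for cytotoxicity, read by sulforhodamine B assay, with a stated time of 48 h (a lower number here means a stronger inhibitor, a higher number a weaker inhibitor), compound 2 `CCN(CC)CCCn1c(=O)/c(=C/c2cc(OC)c(OC)c(OC)c2)s/c1=C1\C(=O)Nc2ccc(Cl)cc21` gives 820 nM. Compound 3 `CCN(CC)CCCn1c(=O)/c(=C/c2cc(OC)c(OC)c(OC)c2)s/c1=C1/C(=O)Nc2ccc(Cl)cc21` gives 820 nM in this assay, and compound 1 `CCN(CC)CCCn1c(=O)/c(=C/c2ccccc2O)s/c1=C1/C(=O)Nc2ccc(C)cc21` gives 14800 nM. Compound 2 therefore stands level with compound 3 at the low end of these three numbers, while compound 1 sits well apart.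

Going by the values given here, only one measured step joins two compounds that differ in a single place: from compound 2 to compound 3 the change was no change at the digits printed from compound 2 to compound 3 (within the scatter), which fits with the fact that compounds 2 and 3 differ only in the configuration as drawn. Compound 1 differs from compound 2 in more than one place, so its value can only be set beside that of compound 2 without being read as a single step.

Compound 4 `CCN(CC)CCCn1c(=O)/c(=C/c2ccc(O)cc2)s/c1=C1\C(=O)Nc2ccc(Cl)cc21` has not yet been measured. It differs from compound 2 by 4-hydroxyphenyl in place of 3,4,5-trimethoxyphenyl on a double-bonded chain carbon bound to an aromatic carbon. Among the compounds with values here, no measured step covers this exchange, so the expectation rests on the two values of compound 1 and compound 2, which show the compound carrying a hydroxyphenyl group at this position with the higher number. On that basis a weakening step is expected from compound 2 to compound 4 of about a 6.1-fold higher number from compound 2 to compound 4 (0.79 log units; beyond the scatter), and for compound 4 in this assay an estimated 5000 nM, with a likely range from 1500 nM to 20000 nM.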

Compound 4, half-maximal inhibitory concentration: 24600 nM
Estimate against measurement, compound 4: 4.9-fold (0.69 log units) below; measured number outside the range, above it.
By their numbers in this assay, from the lowest: compounds 2 and 3 (each within the scatter of the next); then compounds 1 and 4 (each within the scatter of the next).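

In this assay, putting 4-hydroxyphenyl in place of 3,4,5-trimethoxyphenyl on a double-bonded chain carbon bound to an aromatic carbon gives a 30-fold higher number from compound 2 to compound 4 (1.48 log units; beyond the scatter). Going by these compounds alone, this position is therefore sensitive to the group it carries, something the only earlier step could not show, since it gave no change at the digits printed from compound 2 to compound 3 (within the scatter) and concerned configuration alone. The exchange changes the counts of heavy atoms, hydrogen-bond acceptors and hydrogen-bond donors all at once, and nothing given here accounts for the size of this step.

From the compounds shown here alone, it remains open whether the higher number of compound 4 comes from gaining the hydroxy group or from losing the three methoxy groups, and a plain phenyl group or a phenyl ring carrying a single methoxy group at this place would help separate the two. Going by these compounds, it is also open whether the configuration of the double bond would stay without consequence in the 4-hydroxyphenyl series, as it does between compound 2 and compound 3.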